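The source may report more compounds than this note shows. Statements on the series, on what has been measured and on what is new or still open speak of the compounds shown alone.

Three compounds share the core of compound 1 and have been measured in a functional assay on HeLa cells (Homo sapiens) for antiproliferative activity, read by spectrophotometry, with a stated time of 2 days; a higher number here means a weaker inhibitor of growth, a lower number a stronger inhibitor of growth:

Compound 1, `COc1cc(Nc2ncc(C(F)(F)F)c(N3Cc4cccc(N(C)S(C)(=O)=O)c4C3)n2)cc(OC)c1`: 7000 nM
Compound 2, `CN(c1cccc2c1CN(c1nc(Nc3cccc(C(F)(F)F)c3)ncc1C(F)(F)F)C2)S(C)(=O)=O`: 5300 nM
Compound 3, `Cc1cc(C)cc(Nc2ncc(C(F)(F)F)c(N3Cc4cccc(N(C)S(C)(=O)=O)c4C3)n2)c1`: > 30000 nM; for compound 3 this is a limit of the assay, not a number.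

The three differ only in the aryl group on the nitrogen on the aromatic ring. The step of a 1.3-fold lower number from compound 1 to compound 2 (0.12 log units; within the scatter) is within the scatter. Compound 3 stands apart: an at least 4.2-fold higher number from compound 1 to compound 3 (0.63 log units; beyond the scatter) and an at least 5.6-fold higher number from compound 2 to compound 3 (0.75 log units; beyond the scatter), and compound 3 sits at the limit of > 30000 nM in this assay, at which 1 of the 3 values shown sits, so its true value is known only as a limit.

Compound 4, `Cc1ccc(Nc2ncc(C(F)(F)F)c(N3Cc4cccc(N(C)S(C)(=O)=O)c4C3)n2)c(C)c1`, has not yet been measured in this assay. It keeps the same atoms as compound 3 and changes only their arrangement: 2,4-dimethylphenyl in place of 3,5-dimethylphenyl on a nitrogen on an aromatic ring. Among the measured compounds shown here, none of the measured steps moves substituents about within the same aryl ring, so they bear on this change only indirectly; they show that 3,5-dimethylphenyl gives the weakest growth inhibition of the three aryl groups, and nothing shows that 2,4-dimethylphenyl should recover what was lost.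

Compound 4 is therefore expected to remain near the limit at which compound 3 sits, with a step of a number no higher from compound 3 to compound 4 (the limit leaves the size open) that is expected to lie within the scatter, and its estimated value is 30000 nM, ranging from 10000 nM to 100000 nM.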

Compound 4, concentration for 50% growth inhibition: 10600 nM
Compound 4: middle estimate off by 2.8-fold (0.45 log units), on the high side; measured number inside the range.
By their numbers in this assay, from the lowest: compounds 2, 1 and 4 (each within the scatter of the next). At a limit, above all of these: compound 3.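

In this assay, the same atoms in a different arrangement, 2,4-dimethylphenyl in place of 3,5-dimethylphenyl on a nitrogen on an aromatic ring, give an at least 2.8-fold lower number from compound 3 to compound 4 (0.45 log units; beyond the scatter), so at this position the placing of the two methyl groups counts, and not only which groups the aryl ring carries. The figure for compound 3 remains a limit of the assay and not a number, which leaves the upper size of that step unknown: the limit of > 30000 nM in this assay, at which 1 of the 4 values shown sits. The other two steps, a 2.0-fold higher number from compound 2 to compound 4 (0.30 log units; within the scatter) and a 1.5-fold higher number from compound 1 to compound 4 (0.18 log units; within the scatter), both lie within the scatter, so 2,4-dimethylphenyl, 3-(trifluoromethyl)phenyl and 3,5-dimethoxyphenyl cannot be told apart here, and only 3,5-dimethylphenyl stands apart from them.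

The compounds shown leave open whether one methyl group of the 2,4-dimethylphenyl alone would give the same reading in this assay, as a phenyl ring with a single methyl group is not among them. Also open, going by these compounds, is whether an amine or a carboxylic acid on this aryl ring would move the number beyond the scatter of these values.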